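Acetyl to methoxycarbonyl at the limit of the assay

The source may report more compounds than this note shows. Statements on the series, on what has been measured and on what is new or still open speak of the compounds shown alone.

Measured in a functional assay on the whole organism for antagonist activity, with Mus musculus as the target; on this read-out higher numbers stand for an effect only at larger amounts of compound and lower numbers for an effect already at smaller amounts:
compound 1 `CC(=O)N(C)C(C)C#CCn1cncc1C`: 80 mg/kg (a number)
compound 2 `CC(=O)N(C)CC#CCn1ccnc1`: > 100 mg/kg (a limit)
compound 3 `CC(=O)N(C)CC#CCn1cncc1C`: > 100 mg/kg (a limit)

Compound 3 gives > 100 mg/kg, which is a limit and not a number. It thus stands at the limit of > 100 mg/kg in this assay, at which 2 of the 3 values shown sit, and has no exact place on the scale. Compound 4 `COC(=O)N(C)CC#CCn1cncc1C` changes the carbonyl group: methoxy in place of methyl on a carbonyl carbon (acetyl to methoxycarbonyl). The measured steps lie elsewhere: an at least 1.2-fold higher number from compound 1 to compound 3 (0.09 log units; that floor lies within the scatter) for hydrogen in place of methyl on a saturated chain carbon, and a step that the two limits leave unreadable from compound 2 to compound 3 for methyl in place of hydrogen on an aromatic carbon. Neither touches the carbonyl carbon, so no step beyond the scatter is expected in this assay, in either direction. The expected step is a step that the limit leaves unreadable from compound 3 to compound 4 and rests on a limit. For compound 4 the estimate is 120 mg/kg, with an expected range from 60 mg/kg to 250 mg/kg and a further limit likely.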

Compound 4, dose for half-maximal effect: > 100 mg/kg
Compound 4 was reported as a limit; the forecaster's own chance of this, stated with the estimate: 70%; the middle value is on the limit's open side.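

No step can be read from compound 3 to compound 4 because both sit at the same limit of the assay, which is not a number: the limit of > 100 mg/kg in this assay, at which 3 of the 4 values shown sit.

In this assay the compounds shown leave open whether methoxy in place of methyl on a carbonyl carbon changes the dose for half-maximal effect at all.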